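Amino Addition on the Core of Compound 2

The source may report more compounds than this note shows. Statements on the series, on what has been measured and on what is new or still open speak of the compounds shown alone.

Compound 2 `OCC1=C(F)[C@@H](n2cnc3c(NC4CC4)ncnc32)[C@H](O)[C@@H]1O` has given no number in a functional assay on A549 cells (Homo sapiens) for cytotoxicity, read by sulforhodamine B assay, with a stated time of 72 h; on this read-out higher numbers stand for weaker inhibition and lower numbers for stronger inhibition: compound 2 reaches > 100000 nM, which is a limit of the assay and not a measured value. Among the measured compounds shown here, compound 1 `CNc1ncnc2c1ncn2[C@@H]1C(F)=C(CO)[C@@H](O)[C@H]1O` is the one neighbour measured with a number; in this assay compound 1 gives 2390 nM. For the measured compounds named here, the single measured step, an at least 41-fold higher number from compound 1 to compound 2 (1.62 log units; beyond the scatter), runs from that number up to the limit and is the reason that the limit of > 100000 nM in this assay, at which 2 of the 3 values shown sit, holds most of the series. Compound 3 `Nc1nc(O)c2ncn([C@@H]3C(F)=C(CO)[C@@H](O)[C@H]3O)c2n1` sits there too: in this assay compound 3 gives > 100000 nM, which is a limit and not a number.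

Compound 4 `Nc1nc(NC2CC2)c2ncn([C@@H]3C(F)=C(CO)[C@@H](O)[C@H]3O)c2n1` is the next change from compound 2: amino in place of hydrogen on an aromatic carbon, on an aromatic carbon of a six-membered aromatic ring with 2 nitrogen, meta to a cyclopropylamino group. Going by the values given here, no measured step concerns this change; the only one known, the cyclopropyl step from compound 1 to compound 2, does not touch this position. Compound 3 also carries an amino group on its core and reaches only the limit. Starting from a limit, the step of a number no higher from compound 2 to compound 4 (the limit leaves the size open) is expected to be none beyond the scatter. Compound 4 is therefore estimated at 100000 nM, within 20000 nM to 300000 nM, most likely reported as a limit again.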

Compound 4, half-maximal inhibitory concentration: > 100000 nM
Compound 4 ended at the assay's limit (the forecaster's own chance of this, stated with the estimate: 70%); the middle value sits exactly at the limit.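

In this assay compound 4 gives only a limit, so the steps from compound 2 to compound 4 and from compound 3 to compound 4 cannot be read: the limit of > 100000 nM in this assay, at which 3 of the 4 values shown sit.

The compounds shown leave open how far compound 2, compound 3 and compound 4 each lie beyond that limit, and whether the amino group of compound 4 alters cytotoxicity at all.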